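Compound 4: chloro in place of trifluoromethyl

The source may report more compounds than this note shows. Statements on the series, on what has been measured and on what is new or still open speak of the compounds shown alone.

The three measured compounds share one core and differ only at one aromatic ring: compound 1 `CN(c1cccc2c1CN(c1nc(Nc3cccc(Oc4ccccc4)c3)ncc1C(F)(F)F)C2)S(C)(=O)=O`, compound 2 `CN(c1cccc2c1CN(c1nc(Nc3cc(C(F)(F)F)cc(C(F)(F)F)c3)ncc1C(F)(F)F)C2)S(C)(=O)=O` and compound 3 `CN(c1cccc2c1CN(c1nc(Nc3cccc(C(F)(F)F)c3)ncc1C(F)(F)F)C2)S(C)(=O)=O`. In a functional assay on A549 cells (Homo sapiens) for antiproliferative activity, read by spectrophotometry, with a stated time of 2 days (a lower number here means a stronger inhibitor of growth, a higher number a weaker inhibitor of growth), compound 1 gives 19000 nM. Compound 2 reaches only the limit of the assay, > 30000 nM, which is a limit and not a number. Compound 3 likewise stands at a limit, > 30000 nM. Compound 2 therefore stands at the weak end of what the numbers can show, and the step that the two limits leave unreadable from compound 2 to compound 3 cannot be sized because the limit of > 30000 nM in this assay, at which 2 of the 3 values shown sit, holds both of its ends. Among the measured compounds shown here, the only readable step on this ring is an at least 1.5-fold higher number from compound 1 to compound 3 (0.19 log units; that floor lies within the scatter), and its floor lies within the scatter.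

Compound 4 `CN(c1cccc2c1CN(c1nc(Nc3cc(Cl)cc(C(F)(F)F)c3)ncc1C(F)(F)F)C2)S(C)(=O)=O` differs from compound 2 by chloro in place of trifluoromethyl on an aromatic carbon.

For the measured compounds named here, no measured step sizes this exchange; the one step that bears on the same ring, from compound 2, is unreadable, and the one with a number is within scatter. The expectation is therefore no step beyond the scatter, with compound 4 most likely at or near the limit. Compound 4 is estimated at 35000 nM, within 15000 nM to 90000 nM. The expected step that the limit leaves unreadable from compound 2 to compound 4 is none beyond the scatter.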

Compound 4, concentration for 50% growth inhibition: 6700 nM
Estimate against measurement, compound 4: 5.2-fold (0.72 log units) above, and the stated range ends above it.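

In this assay, among the compounds shown here, the position meta to a trifluoromethyl group now gives a readable result for the first time, as chloro brings a step beyond the scatter: an at least 4.4-fold lower number from compound 2 to compound 4 (0.65 log units; beyond the scatter). The same ring with hydrogen at this place gives an at least 4.4-fold lower number from compound 3 to compound 4 (0.65 log units; beyond the scatter), so in these compounds the readable activity goes with chloro specifically, and neither hydrogen nor trifluoromethyl at this place gives a value inside the range of the assay. Both steps are floors and not full sizes, and the step between compound 2 and compound 3 cannot be read, because these two compounds have no number at their end of the comparison: the limit of > 30000 nM in this assay, at which 2 of the 4 values shown sit.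

How far the chloro step truly reaches remains open, as does whether chloro needs the trifluoromethyl group on the same ring, since no compound shown carries chloro with hydrogen in that other place. Also open, as far as these compounds go, is how bromo, methyl, methoxy, an amine or a carboxylic acid would behave at this position, and whether the step seen on A549 cells holds in any other cell line.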